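A few compounds are considered here, and "the series" means these few. Any claim that something is new, unique, unknown or untested is made for them only; others in the source may bear on it.

Working notes on the series. Compound 1 `COc1ccc(/C=C/C(=O)O)c(OC(=O)c2nc(C)c(C)nc2C)c1` carries the free acid on its 2-carboxyethenyl arm; in a functional assay on EA.hy 926 cells (Homo sapiens) for cytotoxicity, read by MTT assay, with stated times of 24 h and 12 h, tested at 12.5 uM (a lower number here means a weaker effect, a higher number a stronger effect of the compound at the concentration tested), compound 1 gives 39.7%. Compound 2 `CCOC(=O)/C=C/c1ccc(OC)cc1OC(=O)c1nc(C)c(C)nc1C` is the corresponding ethyl ester, and in this assay compound 2 gives -57.6%. The change from compound 1 to compound 2 is ethyl in place of hydrogen on an oxygen next to a carbonyl group, and it makes a step of a number 97.3 percentage points lower from compound 1 to compound 2 (beyond the scatter), well beyond the scatter and the largest move in the set.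

Compound 3 `COc1cc(/C=C/C(=O)O)cc(OC)c1OC(=O)c1nc(C)c(C)nc1C` is built on a differently substituted core; how its core differs from that of compound 1 is not broken down here. In this assay compound 3 gives 5.7%, which lies between the values of compound 1 and compound 2, beyond the scatter from each.

Compound 4 `CCOC(=O)/C=C/c1cc(OC)c(OC(=O)c2nc(C)c(C)nc2C)c(OC)c1` has not yet been measured. It differs from compound 3 by ethyl in place of hydrogen on an oxygen next to a carbonyl group, which is the same change as from compound 1 to compound 2 and sits at the same place, described in the same words. Among the compounds with values here, the only precedent is the single pair of compound 1 and compound 2, and the cores of compound 3 and compound 1 are not compared here, so the forecast rests on one step. Within the data shown here, the step from compound 3 to compound 4 in this assay is expected to be a number 75.7 percentage points lower from compound 3 to compound 4 (beyond the scatter), in the same direction as the earlier step but set a little short of it, given the single precedent. Compound 4 is accordingly estimated to give -70% in this assay, with a likely range from -120% to -10%.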

Compound 4, a percentage reported as activity, at one concentration (the size of the read-out at that concentration, not a potency): 96.6%
Compound 4: the middle estimate sits 166.6 percentage points below what was measured; measured number above the stated range.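

In this assay, the change from carboxy to ethoxycarbonyl on the core of compound 3 gives a step of a number 90.9 percentage points higher from compound 3 to compound 4 (beyond the scatter), so the change does not carry over from the core of compound 1 with the same direction. Set side by side, the two steps run in opposite directions, and the gap between them is beyond the scatter: the same change on two cores in this assay, a number 97.3 percentage points lower (beyond the scatter) from compound 1 to compound 2 and a number 90.9 percentage points higher (beyond the scatter) from compound 3 to compound 4, 188.2 percentage points apart, beyond the scatter of two such steps. This shows that, for these two pairs, the outcome of exchanging the free acid for the ethyl ester cannot be read from one core to the other, but it does not show which feature of the two cores goes with the reversal, and with one pair per core at a single concentration it sets no rule for any further core.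

The compounds shown pair only the free acid with the ethyl ester, so it remains open how a methyl ester, an ester with a longer chain or an amide on the same arm would read in this assay on either core. Also open, going by these compounds, is whether a core intermediate between those of compound 1 and compound 3 would follow the first step, the second or neither.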